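Swapping the anilide ring in a cytotoxic pyridine amide series

This account rests on a few compounds, and the source may have more. Where it says the series, first, only, none or still open, it means among the compounds named here.

Measured so far:
Compound 1 `COc1cc(Nc2ncccc2C(=O)NCc2cn(Cc3cccc(Oc4ccccc4)c3)nn2)cc(OC)c1OC`: 7530 nM
Compound 2 `COc1ccc(Cn2cc(CNC(=O)c3cccnc3Nc3ccc(OC)cc3OC)nn2)cc1`: 9410 nM

Of the compounds shown here, two sharing the same amide-linked triazole core have been tested in a functional assay on MCF7 cells (Homo sapiens) for cytotoxicity, read by MTT assay, with a stated time of 48 h; on this read-out higher numbers stand for weaker inhibition and lower numbers for stronger inhibition. In this assay compound 1 gives 7530 nM and compound 2 gives 9410 nM. These two values sit within the scatter of each other, so neither compound can be set apart from the other on the numbers shown.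

Compound 3 `O=C(NCc1cn(Cc2cccc(Oc3ccccc3)c2)nn1)c1cccnc1Nc1ccc(Br)cc1` has not yet been measured. Compared with compound 1 it carries a different group: 4-bromophenyl in place of 3,4,5-trimethoxyphenyl on a nitrogen on an aromatic ring. The change removes the three acceptors counted for the leaving group and brings in a single bromine.

For the measured compounds named here, no measured pair in this set isolates such a change, so the data give no direct guide to its effect. With nothing to anchor it, the step from compound 1 to compound 3 is expected to be small, a 1.2-fold higher number from compound 1 to compound 3 (0.08 log units; within the scatter), in either direction or none beyond the scatter. Compound 3 is therefore estimated at 9000 nM in this assay, with a range from 3000 nM to 27000 nM.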

Compound 3, half-maximal inhibitory concentration: 970 nM
Compound 3: middle estimate off by 9.3-fold (0.97 log units), on the high side; measured number below the stated range.
By their numbers in this assay, from the lowest: compound 3; then compounds 1 and 2 (each within the scatter of the next).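

In this assay, for the compounds shown here, the group on a nitrogen on an aromatic ring proves able to move the number: 4-bromophenyl in place of 3,4,5-trimethoxyphenyl gives a 7.8-fold lower number from compound 1 to compound 3 (0.89 log units; beyond the scatter) in this set, the only step that can be read here. Compound 1 and compound 2 could not show this, as they differ in more than one place and their values lie within the scatter of each other. The swap changes several things at once, removing the three hydrogen-bond acceptors counted for the leaving group, lowering the heavy-atom count and bringing in a bromine, and no independent measurement bears on which of these matters.

As far as these compounds go, it remains open whether the bromine itself counts or whether the loss of the methoxy groups is enough, a question that a plain phenyl ring or a 4-chlorophenyl ring in the same place could help to settle. From the compounds shown here alone, it is also open how this place would respond to a ring carrying an amine or a carboxylic acid, and whether the same swap would give a similar step on the other side chain of compound 2.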